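A step from methylcarbamoyl to propylcarbonyl

The compounds below may be only part of what the source reports. "The series", "measured", "known", "first", "only" and "open" are said of these compounds alone.

In a toxicity assay on NIH3T3 cells (Mus musculus) for cytotoxicity, read by resazurin assay (on this read-out higher numbers stand for an effect only at larger amounts of compound and lower numbers for an effect already at smaller amounts), compound 3 (`CNC(=O)c1ccc(NCc2cncn2Cc2ccc(-c3ccccc3)cc2)cc1-c1ccccc1`) gives > 1000 nM as a limit of the assay and not a number. Compound 1 (`CNC(=O)c1ccc(NCc2cncn2Cc2ccc(-c3ccccc3)cc2N)cc1-c1ccccc1`) gives > 1000 nM as a limit too. Compound 2 (`COC(=O)c1ccc(NCc2cncn2Cc2ccccc2)cc1-c1ccccc1`) gives > 1000 nM as a limit as well. The record in this assay is therefore the limit of > 1000 nM in this assay, at which 3 of the 3 values shown sit, and holds no exact number yet.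

Compound 4 (`CCCC(=O)c1ccc(NCc2cncn2Cc2ccc(-c3ccccc3)cc2)cc1-c1ccccc1`) differs from compound 3 by propyl in place of methylamino on a carbonyl carbon and the change is propyl in place of methylamino on a carbonyl carbon. Going by the values given here, the only measured step that touches compound 3 is a step that the two limits leave unreadable from compound 1 to compound 3 and it is hydrogen in place of amino on an aromatic carbon, a change at another place. Among the compounds with values here, it offers no size to carry over, and no step has been measured at the carbonyl carbon. The expected size is therefore a step that the limit leaves unreadable from compound 3 to compound 4 with no direction beyond the scatter. For compound 4 the estimated value is 1500 nM with an expected range from 400 nM to 6000 nM and the assay may well report only a limit again.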

Compound 4, half-maximal effective concentration: > 10000 nM
Compound 4 ended at the assay's limit; the forecaster's own chance of this, stated with the estimate: 75%; middle value at least 6.6-fold (0.82 log units) from the limit.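

In this assay, compound 3 and compound 4 both end at limits and not at numbers, so the step between them cannot be read. The compounds shown leave open whether swapping methylamino for propyl on the carbonyl carbon changes the cytotoxicity at all, and in which direction.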